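Debromination step carried from one pair to the next

A few compounds are considered here, and "the series" means these few. Any claim that something is new, unique, unknown or untested is made for them only; others in the source may bear on it.

Measured so far:
compound 1 `Cc1cc(O)c(C(=O)/C=C/c2ccccc2)c(-c2ccccc2)c1C(=O)/C=C/c1ccccc1`: 8500 nM
compound 2 `Cc1cc(O)c(C(=O)/C=C/c2ccccc2)c(-c2ccc(Br)cc2)c1C(=O)/C=C/c1ccccc1`: 8000 nM
compound 3 `COc1ccc(/C=C/C(=O)c2c(C)cc(O)c(C(=O)/C=C/c3ccc(OC)cc3)c2-c2ccc(Br)cc2)cc1`: "not active" (no number reported)

In a functional assay on MDA-MB-231 cells (Homo sapiens) for cytotoxicity, read by MTT assay, with a stated time of 24 h (on this read-out higher numbers stand for weaker inhibition and lower numbers for stronger inhibition), compound 2 gives 8000 nM and compound 1 gives 8500 nM. The change between them is hydrogen in place of bromo on an aromatic carbon, and the resulting step of a 1.1-fold higher number from compound 2 to compound 1 (0.03 log units; within the scatter) lies within the scatter. Compound 3 gives "not active" (no number reported) in this assay, without a number. The difference between the cores of compound 2 and compound 3 is not broken down here. Compound 4 `COc1ccc(/C=C/C(=O)c2c(C)cc(O)c(C(=O)/C=C/c3ccc(OC)cc3)c2-c2ccccc2)cc1` differs from compound 3 by hydrogen in place of bromo on an aromatic carbon; the place is the same word for word, so this is the same change. The same size of step, within the scatter, is therefore expected from compound 3 to compound 4 in this assay, resting on a 1.1-fold higher number from compound 2 to compound 1 (0.03 log units; within the scatter). Compound 4 is estimated at 40000 nM, range 10000 nM to 150000 nM, with a real chance that only a limit is reported.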

Compound 4, half-maximal inhibitory concentration: "not active" (no number reported)
No number was reported for compound 4, and the estimate cannot be compared.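

Compound 3 gives "not active" (no number reported) and compound 4 gives "not active" (no number reported), so no new step can be read between them. As far as these compounds go, what the change from 4-bromophenyl to phenyl does on this core stays open. No measured evidence bears on this result.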